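Replacing the 4-fluorophenyl group of compound 2

This account rests on a few compounds, and the source may have more. Where it says the series, first, only, none or still open, it means among the compounds named here.

In a functional assay on HepG2 cells (Homo sapiens) for antiproliferative activity, read by MTT assay (a lower number here means a stronger inhibitor, a higher number a weaker inhibitor), compound 1 (`O=C(Nc1cccc(CNc2ncnc3ccccc23)c1)Nc1ccccc1F`) gives 17500 nM and compound 2 (`O=C(Nc1ccc(F)cc1)Nc1cccc(CNc2ncnc3ccccc23)c1`) gives 41500 nM as the higher number of the two, which makes it the weaker inhibitor. Compound 3 (`O=C(Nc1cccc(CNc2ncnc3ccccc23)c1)Nc1cccc(C(F)(F)F)c1`) has 3-(trifluoromethyl)phenyl in place of 4-fluorophenyl on an amide-type nitrogen. Among the compounds with values here, the only measured step that bears on this is a 2.4-fold higher number from compound 1 to compound 2 (0.38 log units; beyond the scatter) and it was modest, with 4-fluorophenyl taking the place of 2-fluorophenyl on that nitrogen. The expected change is a 1.4-fold lower number from compound 2 to compound 3 (0.14 log units; within the scatter) and so no step beyond the scatter is expected. The estimate for compound 3 is 30000 nM with 10000 nM to 80000 nM as its range.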

Compound 3, half-maximal inhibitory concentration: 40000 nM
Estimate against measurement, compound 3: 1.3-fold (0.12 log units) below; low and high end bracket the measured number.
By their numbers in this assay, from the lowest: compound 1; then compounds 3 and 2 (each within the scatter of the next).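

In this assay, 3-(trifluoromethyl)phenyl on the amide-type nitrogen gives a 1.0-fold lower number from compound 2 to compound 3 (0.02 log units; within the scatter) when it takes the place of 4-fluorophenyl, so this larger group, with three fluorines instead of one, leaves the two compounds indistinguishable. Set against 2-fluorophenyl, the same group gives a 2.3-fold higher number from compound 1 to compound 3 (0.36 log units; beyond the scatter) and thus compound 1 remains apart from both others. Nothing available explains these numbers. Still open, going by these compounds, is whether 2-chlorophenyl would match 2-fluorophenyl, and whether a phenyl ring carrying an amine or a carboxylic acid would give a much lower number.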